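Changing the Side Chain of Compound 1 to Give Compound 4

A few compounds are considered here, and "the series" means these few. Any claim that something is new, unique, unknown or untested is made for them only; others in the source may bear on it.

Three compounds have been measured in a functional assay on the whole organism (Tail, strain ICR) with Mus musculus as the target, in the tail flick test, with a stated time of 150 min, at a dose of 25 umol/kg by the oral route; on this read-out lower numbers stand for a weaker effect and higher numbers for a stronger effect at the one dose given:

compound 1, `NCCCC[C@H](NC(=O)CN(c1nc(Cl)nc2[nH]cnc12)C1CC1)C(=O)OCc1ccccc1`: 9.88%
compound 2, `O=C(O)C[C@H](NC(=O)CN(c1nc(Cl)nc2[nH]cnc12)C1CC1)C(=O)O`: 11.6%
compound 3, `NC(=O)CC[C@H](NC(=O)CN(c1nc(Cl)nc2[nH]cnc12)C1CC1)C(=O)O`: 11.4%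

All three share the same core and differ only in what hangs on the saturated chain carbon two bonds along the chain from an amide-type nitrogen and a carbonyl carbon, and in the group at the carbonyl end. Compound 1 has the lowest of the three numbers, yet its distance to compound 3 and to compound 2 lies within the scatter, so no order among them can be read. Going by the values given here, the single step between measured compounds, a number 0.2 percentage points lower from compound 2 to compound 3 (within the scatter), also stays within the scatter.

Compound 4, `NC(=O)C[C@H](NC(=O)CN(c1nc(Cl)nc2[nH]cnc12)C1CC1)C(=O)OCc1ccccc1`, is compound 1 with a changed side chain: carbamoyl in place of 3-aminopropyl on a saturated chain carbon, two bonds along the chain from an amide-type nitrogen and a carbonyl carbon. Among the compounds with values here, the step from compound 2 to compound 3 is the only comparison that touches this same place, and it exchanged one side chain for another without moving the number beyond the scatter. Within the data shown here, nothing measured so far shows a side-chain change at this place producing a real shift, so the step of a number 0.6 percentage points higher from compound 1 to compound 4 (within the scatter) is expected to stay within the scatter. For compound 4 in this assay a value of 10.5% is expected, lying between 4% and 18%.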

Compound 4, a percentage reported as activity, at one dose (the size of the read-out at that dose, not a potency): 13.5%
Beside the measured number, compound 4's estimate is 3 percentage points below it; measured number inside the range.
By their numbers in this assay, from the lowest: compounds 1, 3, 2 and 4 (each within the scatter of the next).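

Exchanging 3-aminopropyl for carbamoyl at this place, with the group at the carbonyl end held the same, gives a number 3.6 percentage points higher from compound 1 to compound 4 (within the scatter) in this assay. This is a larger structural exchange than the one from compound 2 to compound 3: a side chain ending in an amine gives way to a shorter one that carries an amide, and even so the read-out does not move beyond the scatter, so this amine is not shown to be needed for the effect seen at this one dose. No measured evidence on the compounds explains this outcome, so it stands as an observation only.

These compounds leave open whether a side chain of another kind at this place, such as a plain methyl, a phenyl ring or a longer chain ending in a carboxylic acid, would move the number beyond the scatter. A single dose at a single time also leaves open whether compound 1 and compound 4 would still read alike at other doses or times.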